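Replacing bromo with hydrogen: what to expect

The source may hold more compounds than are shown below. What is called first, only, known or untested is meant among the compounds shown, and "the series" means these compounds.

Measured so far in a functional assay on MGC-803 cells (Homo sapiens) for antiproliferative activity, read by CellTiter-Glo, with a stated time of 72 h; on this read-out higher numbers stand for weaker inhibition and lower numbers for stronger inhibition

Compound 1 `COc1ccccc1-c1cc(/C=C/c2ccc(C(=O)NO)cc2)ccn1` gives 6350 nM
Compound 2 `O=C(NO)c1ccc(/C=C/c2ccnc(-c3ccc(F)cc3)c2)cc1` gives > 10000 nM (a limit)
Compound 3 `O=C(NO)c1ccc(/C=C/c2ccnc(Br)c2)cc1` gives > 10000 nM (a limit)

Compound 3 has no exact number and stands at the limit of > 10000 nM in this assay, at which 2 of the 3 values shown sit. The next structure, compound 4 `O=C(NO)c1ccc(/C=C/c2ccncc2)cc1`, has hydrogen in place of bromo on an aromatic carbon.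

Three measured steps change the group on this same carbon. One is an at least 1.5-fold higher number from compound 1 to compound 3 (0.19 log units; that floor lies within the scatter), and another is an at least 1.5-fold higher number from compound 1 to compound 2 (0.19 log units; that floor lies within the scatter). The third is a step that the two limits leave unreadable from compound 2 to compound 3. None of these steps brings in hydrogen, and none gives a size that clearly exceeds the scatter. Compound 1 alone gives a number, and it carries the large 2-methoxyphenyl group.

Compound 4 has neither that group nor the bromo of compound 3. No step beyond the scatter is therefore expected in this assay, in either direction. The estimated step is a step that the limit leaves unreadable from compound 3 to compound 4. Compound 4 is estimated at 12000 nM, with an expected range from 5000 nM to 30000 nM. The measurement may well return only a limit again.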

Compound 4, half-maximal inhibitory concentration: 3930 nM
The estimate for compound 4 lay 3.1-fold (0.48 log units) above the measured number, and the stated range ends above it.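

Among these compounds, putting hydrogen on this carbon, next to the ring nitrogen, gives the first change at this position that clearly exceeds the scatter in this assay: there is an at least 2.5-fold lower number from compound 3 to compound 4 (0.40 log units; beyond the scatter), and also an at least 2.5-fold lower number from compound 2 to compound 4 (0.40 log units; beyond the scatter). The comparison with the third substituent comes out differently, with a 1.6-fold lower number from compound 1 to compound 4 (0.21 log units; within the scatter), so among these four compounds the number of atoms brought in does not set the order: bromo, a single heavy atom, and the much larger 4-fluorophenyl both give weaker inhibition than hydrogen, while 2-methoxyphenyl cannot be told apart from it. The two steps beyond the scatter are only minimum sizes, and their true sizes stay unknown because compound 2 and compound 3 give no exact number: the limit of > 10000 nM in this assay, at which 2 of the 4 values shown sit.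

Still open is whether any group on this carbon can give clearly stronger inhibition than hydrogen, as no compound shown does so. An amine or a methyl group here would show whether other small groups match bromo or hydrogen, and an unsubstituted phenyl would help separate the two substituted phenyl results.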